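The source may hold more compounds than are shown below. What is called first, only, known or untested is meant among the compounds shown, and "the series" means these compounds.

The set comprises three measured compounds that share one core. Compound 1 `O=C1C(=O)N(CN(c2ccccc2)c2ccccc2)c2cccc(Cl)c21` was tested in a functional assay on MDA-MB-231 cells (Homo sapiens) for cytotoxicity, read by sulforhodamine B assay, with a stated time of 48 h (on this read-out higher numbers stand for weaker inhibition of growth and lower numbers for stronger inhibition of growth), where compound 1 gives 31400 nM. Compound 2 `CCN(CC)CN1C(=O)C(=O)c2c(Br)cccc21` gives 20200 nM in this assay, and compound 3 `O=C1C(=O)N(CN2CCCCC2)c2cccc(Cl)c21` gives 26500 nM in this assay. Compound 1 has the highest of the three numbers, but its distance to compound 3 and its distance to compound 2 both lie within the usual scatter of repeated measurements, so the three compounds cannot be set in any order on these data.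

Compound 4 `O=C1C(=O)N(CN(c2ccccc2)c2ccccc2)c2cccc(Br)c21` has not yet been measured. It differs from compound 1 by bromo in place of chloro on an aromatic carbon. Among the measured compounds shown here, no measured pair in the set shows this exchange on its own: compound 2 carries a bromo group, but also a different group elsewhere on the core, so its value of 20200 nM does not isolate the halogen change. With nothing in the set pointing either way, the step is expected to be small and in no particular direction, not beyond the scatter. The expected step is a 1.1-fold lower number from compound 1 to compound 4 (0.05 log units; within the scatter). Compound 4 is therefore estimated to give 28000 nM in this assay, with a range from 12000 nM to 65000 nM.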

Compound 4, concentration for 50% growth inhibition: 51100 nM
Compound 4: middle estimate off by 1.8-fold (0.26 log units), on the low side; the measured number falls inside the stated range.
By their numbers in this assay, from the lowest: compounds 2, 3, 1 and 4 (each within the scatter of the next, the first and the last beyond it).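

Among the compounds shown here, with compound 1 and compound 4, bromo in place of chloro on this aromatic carbon, ortho to a fused ring and meta to a fused ring, can be read on its own for the first time, which compound 2 could not offer. In this assay the exchange amounts to a 1.6-fold higher number from compound 1 to compound 4 (0.21 log units; within the scatter), a step within the usual scatter, so on the core of compound 1 the two halogens cannot be told apart at this position. No independent measurement bears on this result, and the data offer no account of it.

As far as these compounds go, the pair covers only two halogens and only the group carried on the ring nitrogen by compound 1 and compound 4, so it remains open whether the same exchange would also stay within the scatter with the other groups found on that nitrogen in compound 2 and compound 3. From the compounds shown here alone, it is also open how this aromatic carbon would respond to something other than chloro or bromo, such as fluoro, a methoxy group, an amine or a carboxylic acid.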